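Swapping an acetyl cap for a 4-methylbenzoyl cap

A few compounds are considered here, and "the series" means these few. Any claim that something is new, unique, unknown or untested is made for them only; others in the source may bear on it.

Measured compounds:
compound 1, `CC(=O)N1CCN(Cc2nc3ccccc3n2Cc2cccc(C)c2)CC1`: 70.3%
compound 2, `Cc1cccc(Cn2c(OC3CCN(C(=O)C4CC4)CC3)nc3ccccc32)c1`: 80.6%
compound 3, `COc1cccc(Cn2c(CN3CCN(C(=O)C4CC4)CC3)nc3ccccc32)c1`: 44.4%

Of the compounds shown here, three sharing one core have been tested in an assay on isolated protein for inhibition of aldehyde dehydrogenase 1A1 (Homo sapiens), read by spectrophotometry, tested at 10 uM; a lower number here means less inhibition, a higher number more inhibition at the concentration tested (going by the name of the read-out). Compound 1 gives 70.3%, the second highest of the three numbers. Compound 2 lies nearest to it, at 80.6%, a gap that goes beyond the usual scatter of this assay. Compound 3 is furthest away, at 44.4%, again a gap beyond the scatter. Compound 1 thus sits between its two neighbours, closer to the higher one.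

The untested compound 4, `Cc1ccc(C(=O)N2CCN(Cc3nc4ccccc4n3Cc3cccc(C)c3)CC2)cc1`, differs from compound 1 in one place: 4-methylphenyl in place of methyl on a carbonyl carbon. Put another way, the acetyl group on the amide-type nitrogen in a ring becomes a (4-methylphenyl)carbonyl group, while the rest of compound 1 is kept.

Among the compounds with values here, no measured pair here separates this exact change, so its size is open. Because compound 1 gives 70.3% and both neighbours keep the same core with a differing group at that position, a step from compound 1 to compound 4 of about a number 2.7 percentage points higher from compound 1 to compound 4 (within the scatter) is expected, not beyond the scatter in either direction. Compound 4 is therefore estimated at 73%, with a range from 52% to 90%.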

Compound 4, a percentage reported as inhibition, at one concentration (the size of the read-out at that concentration, not a potency): 64.9%
Compound 4: middle estimate off by 8.1 percentage points, on the high side; low and high end bracket the measured number.
By their numbers in this assay, from the lowest: compound 3; then compounds 4 and 1 (each within the scatter of the next); then compound 2.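

In this assay, the change from acetyl to (4-methylphenyl)carbonyl gives the only direct reading of this position among the compounds shown, with a number 5.4 percentage points lower from compound 1 to compound 4 (within the scatter) on an otherwise unchanged molecule. The earlier compounds shown here could not show this, as each differs from the others in more than one place. For this pair, the group on the carbonyl carbon can go from methyl, with 1 heavy atom, to 4-methylphenyl, with 7 heavy atoms and a six-membered aromatic ring, and the two values still lie within the usual scatter of each other, although no measurement shown here accounts for that result.

Still open, as far as these compounds go, is whether other groups on this carbonyl carbon, such as an amine, a carboxylic acid or a longer carbon chain, would also leave the number within the scatter of compound 1. From the compounds shown here alone, it is also open whether the same swap would read alike on compound 2 or compound 3, which carry a cyclopropyl group at this carbonyl and differ elsewhere too.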